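The source may report more compounds than this note shows. Statements on the series, on what has been measured and on what is new or still open speak of the compounds shown alone.

Measured in a functional assay on the whole organism for agonist activity, with Mus musculus as the target; a lower number here means that less compound is needed, a higher number that more compound is needed for the effect:

Compound 1 `CC(=O)N(C)CC#CCn1ccnc1`: 1.4 mg/kg
Compound 2 `CCOC(=O)N(C)CC#CCN1CCCC1`: > 100 mg/kg

Compound 2 has no number in this assay, and its > 100 mg/kg is a limit of the assay. It stands as follows: the limit of > 100 mg/kg in this assay, at which 1 of the 2 values shown sits.

Compound 3 `CCOC(=O)N(C)CC#CCn1ccnc1` has 1H-imidazol-1-yl in place of pyrrolidin-1-yl on a saturated chain carbon bound to a triple-bonded carbon, as counted here: 1H-imidazol-1-yl in place of pyrrolidin-1-yl on a saturated chain carbon bound to a triple-bonded carbon.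

Among the measured compounds shown here, no measured pair isolates this change. Compound 1 also carries 1H-imidazol-1-yl and gives 1.4 mg/kg, but it is not otherwise identical to compound 3, so it is only a rough guide. A substantial move toward lower doses in this assay is expected, though its size is uncertain with no number for compound 2 as a starting point. The expected change is an at least 6.6-fold lower number from compound 2 to compound 3 (0.82 log units; beyond the scatter). For compound 3 the estimated value is 15 mg/kg, with an expected range of 3 mg/kg to 80 mg/kg.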

Compound 3, dose for half-maximal effect: > 100 mg/kg
Compound 3: no number, only a limit; the forecaster's own chance of this, stated with the estimate: 30%; middle value at least 6.6-fold (0.82 log units) away from the limit.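

In this assay, compound 3 gives > 100 mg/kg, which is a limit of the assay and not a number. The step for 1H-imidazol-1-yl in place of pyrrolidin-1-yl cannot be read, since compound 2 and compound 3 both end in a limit: the limit of > 100 mg/kg in this assay, at which 2 of the 3 values shown sit.

With 1H-imidazol-1-yl present in both compounds, ethoxy in place of methyl on a carbonyl carbon gives an at least 71-fold higher number from compound 1 to compound 3 (1.85 log units; beyond the scatter), so 1H-imidazol-1-yl alone does not secure a low dose, and the group on the carbonyl carbon counts as well.

Whether 1H-imidazol-1-yl offers any gain over pyrrolidin-1-yl remains open: the compounds shown hold no pair with a number at both ends for that change. Also open, going by these compounds, is where a methoxy or a dimethylamino group on the carbonyl carbon would fall relative to methyl and ethoxy.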